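The compounds below may be only part of what the source reports. "The series", "measured", "known", "first", "only" and "open" are said of these compounds alone.

Compound 1 `O=C(Nc1cccc(Cl)c1)Nc1cc2ncncc2cc1OCc1ccccc1`: 6400 nM
Compound 2 `O=C(Nc1cccc(Cl)c1)Nc1cc2ncncc2cc1OCc1ccccc1Cl`: 2800 nM

In a functional assay on GBM3 cells (Homo sapiens) for antiproliferative activity, read by WST assay, with a stated time of 72 h (on this read-out higher numbers stand for weaker inhibition and lower numbers for stronger inhibition), compound 1 gives the highest of the two numbers; its nearest neighbour is compound 2, reached by the step of a 2.3-fold lower number from compound 1 to compound 2 (0.36 log units; beyond the scatter) through chloro in place of hydrogen on an aromatic carbon. Compound 3 `O=C(Nc1ccc(C(F)(F)F)cc1)Nc1cc2ncncc2cc1OCc1ccccc1` differs from compound 1 by 4-(trifluoromethyl)phenyl in place of 3-chlorophenyl on an amide-type nitrogen. Going by the values given here, no measured step touches the amide-type nitrogen; the one known step concerns a different ring and does not bear on this change. Among the compounds with values here, with no step to lean on, no change beyond the scatter is expected. For compound 3 the estimate is 5500 nM, range 2000 nM to 15000 nM, an expected step of a 1.2-fold lower number from compound 1 to compound 3 (0.07 log units; within the scatter).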

Compound 3, half-maximal inhibitory concentration: 3700 nM
Compound 3: middle estimate off by 1.5-fold (0.17 log units), on the high side; the measured number falls inside the stated range.
By their numbers in this assay, from the lowest: compounds 2, 3 and 1 (each within the scatter of the next, the first and the last beyond it).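

First read of the group on the amide-type nitrogen: in this assay, 4-(trifluoromethyl)phenyl in place of 3-chlorophenyl gives a step that stays within the scatter (a 1.7-fold lower number from compound 1 to compound 3 (0.24 log units; within the scatter)). This position therefore accepts this exchange of one substituted phenyl for another without a change that can be told from the scatter. No measured evidence bears on this result. Open, going by these compounds, is whether a carboxylic acid or an amine on that phenyl, or a longer chain in its place, moves the number beyond the scatter. Also open, on these data alone, is how this exchange behaves alongside the chloro of compound 2.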